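A few compounds are considered here, and "the series" means these few. Any claim that something is new, unique, unknown or untested is made for them only; others in the source may bear on it.

Measured compounds:
compound 1 `COc1cc(NC(C)CCCNC(=O)NNC(=O)NCCCCCO)c2ncccc2c1` gives 54%
compound 2 `COc1cc(NC(C)CCCNC(=O)NNC(=O)NCCO)c2ncccc2c1` gives 27%

In a physicochemical assay for inhibition, read by spectrophotometry, tested at 100 uM (a lower number here means less inhibition, a higher number more inhibition at the concentration tested (going by the name of the read-out)), compound 2 stands lowest of the two numbers shown; its nearest neighbour, compound 1, sits a step of a number 27 percentage points lower from compound 1 to compound 2 (beyond the scatter) away. Compound 3 `COc1cc(NC(C)CCCNC(=O)NNC(=O)N(CCO)CCO)c2ncccc2c1` has not yet been measured in this assay. It differs from compound 2 by 2-hydroxyethyl in place of hydrogen on an amide-type nitrogen. Within the data shown here, only one measured step exists here, the one from compound 1 to compound 2, which was modest and beyond the scatter and ran from a longer hydroxyalkyl group to a shorter one, with inhibition falling. The change to compound 3 adds a second such group rather than lengthening the first, so that step bears on it only loosely. Compound 3 is expected to show a step of a number 13 percentage points higher from compound 2 to compound 3 (beyond the scatter), a gain that may or may not exceed the scatter. The estimate for compound 3 in this assay is 40%, with a range from 15% to 65%.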

Compound 3, a percentage reported as inhibition, at one concentration (the size of the read-out at that concentration, not a potency): 43%
The estimate for compound 3 lay 3 percentage points below the measured number; low and high end bracket the measured number.
By their numbers in this assay, from the lowest: compound 2; then compound 3; then compound 1.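

In this assay, among these compounds, 2-hydroxyethyl in place of hydrogen on the amide-type nitrogen gave a number 16 percentage points higher from compound 2 to compound 3 (beyond the scatter), showing that a second substituent on this nitrogen can raise the read-out, whereas the earlier compounds varied only a single hydroxyalkyl chain there. The second arm did not fully match the longer single chain: bis(2-hydroxyethyl)amino in place of (5-hydroxypentyl)amino on the carbonyl carbon gave a number 11 percentage points lower from compound 1 to compound 3 (beyond the scatter), leaving compound 1 highest of the three. Nothing available explains either step.

The compounds shown leave open whether the gain on this nitrogen needs the hydroxy group, which a plain ethyl group in place of 2-hydroxyethyl would test, and whether a second 5-hydroxypentyl chain would go beyond compound 1. They also leave open how an amine or a carboxylic acid in place of the hydroxy would read.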